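The source may hold more compounds than are shown below. What is called first, only, known or untested is meant among the compounds shown, and "the series" means these compounds.

Of the compounds shown here, three sharing one core have been measured in a functional assay on MCF7 cells (Homo sapiens) for cytotoxicity, read by MTT assay, with a stated time of 72 h; on this read-out lower numbers stand for stronger inhibition and higher numbers for weaker inhibition. Compound 1 `COc1cccc(/C=C2\CCC/C(=C\c3ccc(Br)cc3)C2=O)c1OC` gives 13800 nM, compound 2 `COc1cccc(/C=C2\CCC/C(=C\c3cccc(OC)c3OC)C2=O)c1` gives 5900 nM, and compound 3 `COc1ccc(/C=C2\CCC/C(=C\c3cccc(OC)c3OC)C2=O)cc1` gives 18600 nM. Compound 3 stands level with one neighbour and above the other: a 1.3-fold higher number from compound 1 to compound 3 (0.13 log units; within the scatter), whereas a 3.2-fold higher number from compound 2 to compound 3 (0.50 log units; beyond the scatter).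

Compound 4 `COc1ccc(/C=C2\CCC/C(=C\c3cccc(OC)c3OC)C2=O)cc1OC` differs from compound 3 by methoxy in place of hydrogen on an aromatic carbon, ortho to a methoxy group. Among the compounds with values here, no measured step adds a group in this way, so the evidence is indirect. Compound 2 is the nearest guide, since its 3-methoxyphenyl gives 5900 nM. Compound 4 keeps the methoxy group of compound 3 and gains a second one on that ring, so it may move part of the way towards compound 2. A modest step to a lower number is therefore expected in this assay, smaller than the modest gap between those two compounds. The expected change is a 2.1-fold lower number from compound 3 to compound 4 (0.32 log units; beyond the scatter). For compound 4 the estimated value is 9000 nM, with an expected range from 4000 nM to 20000 nM.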

Compound 4, half-maximal inhibitory concentration: 6500 nM
Beside the measured number, compound 4's estimate is 1.4-fold (0.14 log units) above it, within the range that was stated.
By their numbers in this assay, from the lowest: compounds 2 and 4 (each within the scatter of the next); then compounds 1 and 3 (each within the scatter of the next).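

In this assay, a methoxy group placed on an aromatic carbon, ortho to a methoxy group, gives a 2.9-fold lower number from compound 3 to compound 4 (0.46 log units; beyond the scatter), the first measured case of adding a group to this ring rather than swapping one. The same kind of addition starting from the other side of the pair gives a 1.1-fold higher number from compound 2 to compound 4 (0.04 log units; within the scatter), so here the extra methoxy counts when it joins the methoxy of compound 3 but makes no clear difference when it joins that of compound 2. Nothing measured here explains why these two additions differ.

Still open, on these data alone, is whether the gain belongs to methoxy itself or would also appear with a hydroxy group, an ethoxy group or an amine on the same carbon. A third methoxy on this ring also remains untested among the compounds shown.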